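The compounds below may be only part of what the source reports. "The series", "measured", "known", "first", "only" and "open" are said of these compounds alone.

Compound 1 `Cn1c(-c2ccc([N+](=O)[O-])cc2)nc2cc(C(F)(F)F)ccc21` in an ADME assay on BHK cells (Mesocricetus auratus) for cytotoxicity, read by MTT assay, with a stated time of 96 h (on this read-out higher numbers stand for lower toxicity in this test and lower numbers for higher toxicity in this test), gives only > 100000 nM, which is a limit of the assay and not a number (the limit of > 100000 nM in this assay, at which 1 of the 3 values shown sits). Compound 2 `O=[N+]([O-])c1ccc(-c2nc3cc(C(F)(F)F)ccc3[nH]2)cc1` in this assay gives 18000 nM. Among the measured compounds shown here, the single measured step, an at least 5.5-fold lower number from compound 1 to compound 2 (0.74 log units; beyond the scatter), is hydrogen in place of methyl on an aromatic nitrogen. Compound 3 `O=C(CN1CCCC1)Nc1ccc(-c2nc3ccccc3[nH]2)cc1`, with hydrogen on the aromatic nitrogen and an amide on an aromatic carbon, gives 55000 nM in this assay. Compound 4 `CCC(=O)Nc1ccc(-c2nc3cc(C(F)(F)F)ccc3n2C)cc1` keeps the methyl on the aromatic nitrogen and differs from compound 1 by propanoylamino in place of nitro on an aromatic carbon. For the measured compounds named here, no measured step covers this change; an at least 5.5-fold lower number from compound 1 to compound 2 (0.74 log units; beyond the scatter) concerns another part of the molecule and does not bear on it. In this assay compound 4 is therefore expected to stay near the limit, the expected step being a number no higher from compound 1 to compound 4 (the limit leaves the size open), within the scatter. The estimate for compound 4 is 100000 nM, between 40000 nM and 250000 nM.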

Compound 4, half-maximal cytotoxic concentration: > 100000 nM
Compound 4: a limit, no number; the forecaster's own chance of this, stated with the estimate: 55%; the middle value lies on the limit itself.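

Compound 1 and compound 4 each give only a limit, not a number, and the step between them cannot be read: the limit of > 100000 nM in this assay, at which 2 of the 4 values shown sit. The compounds shown leave open how propanoylamino in place of nitro changes the number in this assay.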